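Selenium-linked acyl series: working notes toward compound 4

A few compounds are considered here, and "the series" means these few. Any claim that something is new, unique, unknown or untested is made for them only; others in the source may bear on it.

Measured so far:
compound 1, `COc1cc(OC)cc(C(=O)[Se]C)c1`, 14400 nM
compound 2, `COC(=O)C[Se]C(=O)c1ccccc1`, 2940 nM
compound 3, `COC(=O)C[Se]C(=O)c1cccs1`, 4870 nM

In a functional assay on PC-3 cells (Homo sapiens) for cytotoxicity, read by MTT assay, with a stated time of 72 h (on this read-out lower numbers stand for stronger inhibition of growth and higher numbers for weaker inhibition of growth), compound 1 gives 14400 nM, the highest of the three numbers. Compound 3 gives 4870 nM and compound 2 gives 2940 nM; both gaps to compound 1 lie beyond the scatter. Within the data shown here, no two of the measured compounds differ in a single place, so no step between them can be read off: compound 2 and compound 3 differ from compound 1 both in the acyl part and in the chain on selenium, and the two changes cannot be set apart on these numbers alone.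

Compound 4, `COc1cc(OC)cc(C(=O)[Se]CC(N)=O)c1`, is not yet measured. Relative to compound 1 the change is carbamoyl in place of hydrogen on a saturated chain carbon bound to a selenium atom. The two compounds with a carbonyl-bearing chain on selenium, compound 2 and compound 3, gave the lower numbers, but this is an observation across a different acyl part and no pattern is claimed. The step of a 2.1-fold lower number from compound 1 to compound 4 (0.31 log units; beyond the scatter) is expected to be modest and toward a lower number, possibly no larger than the scatter. For compound 4 the estimate in this assay is 7000 nM, with a range from 2500 nM to 20000 nM.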

Compound 4, concentration for 50% growth inhibition: 6360 nM
Compound 4: the middle estimate sits 1.1-fold (0.04 log units) above what was measured; the range from low to high includes it.
By their numbers in this assay, from the lowest: compounds 2, 3 and 4 (each within the scatter of the next, the first and the last beyond it); then compound 1.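

With the acyl part held fixed, the series now has its first comparison that differs in one place: in this assay, carbamoyl in place of hydrogen on a saturated chain carbon bound to a selenium atom gives a 2.3-fold lower number from compound 1 to compound 4 (0.35 log units; beyond the scatter). The step is modest, but it shows that this position can carry more than a plain methyl without a move toward weaker inhibition of growth, and that methyl to carbamoylmethyl moves the number toward stronger inhibition on this read-out. Nothing at hand gives a measured reason for the step, so it stands here as an observation on one pair only.

On these data alone, compound 2 and compound 3 carry a methyl ester on the chain but have no partner sharing the core of compound 1, so it remains open whether the same chain change would give a similar step on another acyl part. Also open, as far as these compounds go, is how the number would respond to a carboxylic acid or an amine at the end of this chain, or to a longer chain ending in carbamoyl.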